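Capping an Aniline on Two Cores: Measured and Expected

A few compounds are considered here, and "the series" means these few. Any claim that something is new, unique, unknown or untested is made for them only; others in the source may bear on it.

Measured so far:
compound 1 `C=C(Br)C(=O)Nc1cccc(-c2cn3nc(Cc4ccc(Cl)cc4)sc3n2)c1` — 3300 nM
compound 2 `Nc1cccc(-c2cn3nc(Cc4ccc(Cl)cc4)sc3n2)c1` — 42000 nM
compound 3 `Nc1cccc(-c2cn3c(-c4ccccc4)csc3n2)c1` — 29000 nM

In a functional assay on CCRF-CEM cells (Homo sapiens) for inhibition, read by cell counting, with a stated time of 3 days (a lower number here means a stronger inhibitor, a higher number a weaker inhibitor), compound 2 gives 42000 nM, while compound 1 gives 3300 nM. The step of a 13-fold lower number from compound 2 to compound 1 (1.10 log units; beyond the scatter) belongs to the change ((1-bromoethenyl)carbonyl in place of hydrogen on a nitrogen on an aromatic ring). Compound 3 gives 29000 nM, close to compound 2 in this assay; the difference between the two cores is not broken down here. Compound 4 `C=C(Br)C(=O)Nc1cccc(-c2cn3c(-c4ccccc4)csc3n2)c1` is compound 3 carrying the same change, ((1-bromoethenyl)carbonyl in place of hydrogen on a nitrogen on an aromatic ring), at a place described in identical terms. Compound 4 is expected to show a step of a 12-fold lower number from compound 3 to compound 4 (1.06 log units; beyond the scatter), resting on the step of a 13-fold lower number from compound 2 to compound 1 (1.10 log units; beyond the scatter) seen on the other core. Compound 4 is therefore estimated at 2500 nM, expected to fall between 800 nM and 8000 nM.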

Compound 4, half-maximal inhibitory concentration: 2800 nM
Compound 4: the middle estimate sits 1.1-fold (0.05 log units) below what was measured, within the range that was stated.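

In this assay, the same change on the second core gives a 10-fold lower number from compound 3 to compound 4 (1.02 log units; beyond the scatter), and the two cores agree in the size of the step: the same change on two cores in this assay, a 13-fold lower number (1.10 log units; beyond the scatter) from compound 2 to compound 1 and a 10-fold lower number (1.02 log units; beyond the scatter) from compound 3 to compound 4, 1.2-fold (0.09 log units) apart, within the scatter of two such steps.
Within this pair of cores, then, the (1-bromoethenyl)carbonyl change carries over from one core to the other with its size intact. This does not show that it would do so on any further core or in another assay, and it does not explain why the number falls.

The compounds shown leave open how much of the step depends on the bromine or on the double bond. An acetyl or propenoyl group on the same nitrogen could answer this on either core.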